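The source may report more compounds than this note shows. Statements on the series, on what has been measured and on what is new or still open speak of the compounds shown alone.

For the measured compounds named here, in an ADME assay on Vero cells (Chlorocebus sabaeus) for cytotoxicity, with a stated time of 5 days (on this read-out higher numbers stand for weaker inhibition and lower numbers for stronger inhibition), the series so far yields limits only. Compound 1 `[N-]=[N+]=N[C@H]1C[C@H](n2cnc3c(NCCCCCO)nc(N)nc32)O[C@@H]1CO` gives > 100000 nM, which is a limit and not a number. Compound 2 `CN(C)c1nc(N)nc2c1ncn2[C@H]1C[C@H](N=[N+]=[N-])[C@@H](CO)O1` gives > 100000 nM, again a limit. Compound 3 `C#CCNc1nc(N)nc2c1ncn2[C@H]1C[C@H](N=[N+]=[N-])[C@@H](CO)O1` gives > 100000 nM, also a limit, so compound 3 has no measured number to start from.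

Compound 4 `C=CCN(C)c1nc(N)nc2c1ncn2[C@H]1C[C@H](N=[N+]=[N-])[C@@H](CO)O1` carries allyl(methyl)amino in place of propargylamino on an aromatic carbon, and the counted difference is allyl(methyl)amino in place of propargylamino on an aromatic carbon.

Going by the values given here, three measured steps bear on this change, all of them exchanges of the amino substituent on that same aromatic carbon. They are a step that the two limits leave unreadable from compound 1 to compound 2, a step that the two limits leave unreadable from compound 2 to compound 3 and a step that the two limits leave unreadable from compound 1 to compound 3. None of them has a size that can be read, so they set no scale for the new step and give it no direction.

The expectation rests on (the limit of > 100000 nM in this assay, at which 3 of the 3 values shown sit). In this assay no step beyond the scatter is expected, in either direction. The expected step is a number no higher from compound 3 to compound 4 (the limit leaves the size open). The estimate for compound 4 is 100000 nM, with an expected range of 50000 nM to 200000 nM, and a further report as a limit is the likeliest outcome.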

Compound 4, half-maximal inhibitory concentration: 32000 nM
Compound 4: the middle estimate sits 3.1-fold (0.49 log units) above what was measured; the measured number lies below the stated range.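

In this assay, the amino substituent on this aromatic carbon proves able to bring the read-out into a measurable range, which the earlier exchanges there could not show, since none of those steps can be read. Allyl(methyl)amino gives an at least 3.1-fold lower number from compound 3 to compound 4 (0.49 log units; beyond the scatter) where it replaces propargylamino, and an at least 3.1-fold lower number from compound 1 to compound 4 (0.49 log units; beyond the scatter) where it replaces (5-hydroxypentyl)amino. The smallest change is vinyl in place of hydrogen on a saturated chain carbon bound to a nitrogen on an aromatic ring, with an at least 3.1-fold lower number from compound 2 to compound 4 (0.49 log units; beyond the scatter), and the true size of all three steps stays open, as the other compounds remain at the top of the range: the limit of > 100000 nM in this assay, at which 3 of the 4 values shown sit.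

The compounds shown do not separate the contribution of the double bond from that of chain length, which propyl(methyl)amino would address, nor the contribution of the methyl on that nitrogen, which plain allylamino would address. Also open, on these data alone, is whether the trend continues with larger substituents such as diallylamino or a longer alkenyl chain.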